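This account rests on a few compounds, and the source may have more. Where it says the series, first, only, none or still open, it means among the compounds named here.

Measured so far in an in vitro assay on Sf21 cells for inhibition of high affinity 3',5'-cyclic-AMP phosphodiesterase 7A (Homo sapiens); on this read-out higher numbers stand for weaker inhibition and lower numbers for stronger inhibition:
compound 1 `CNc1nc(NC2(C#N)CCCCC2)nc(-n2cccn2)n1` — assay limit only, > 5000 nM
compound 2 `CNc1nc(Nc2ccccc2)nc(NC2(C#N)CCCCC2)n1` — assay limit only, > 5000 nM

Compound 2 stands at the assay limit in this assay, with no number behind it. The same holds for compound 1, so both values shown are limits (the limit of > 5000 nM in this assay, at which 2 of the 2 values shown sit). For the measured compounds named here, the single one-place step among the measured compounds, a step that the two limits leave unreadable from compound 1 to compound 2, is therefore unreadable: the two limits leave its size open.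

The next compound, compound 3 `CNc1nc(C#N)nc(NC2(C#N)CCCCC2)n1`, differs from compound 2 by cyano in place of anilino on an aromatic carbon. Going by the values given here, no measured step bears on this change; the only step in the set is unreadable, and nothing in the measured pair tells in which direction the exchange of anilino for cyano would move this assay.

With both measured compounds at the limit, compound 3 is expected most likely to sit at the limit as well. The estimate for compound 3 in this assay is 10000 nM, with a range from 2000 nM to 50000 nM. The step this estimate implies, a step that the limit leaves unreadable from compound 2 to compound 3, is expected to be no readable change.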

Compound 3, half-maximal inhibitory concentration: > 1000 nM
Compound 3 was reported as a limit; the forecaster's own chance of this, stated with the estimate: 85%; the middle value lies beyond the limit too.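

In this assay compound 3 gives > 1000 nM, a limit and not a number. For the compounds shown here, no step among compound 1, compound 2 and compound 3 can be read, as all three values are limits. The compounds shown leave open whether 1H-pyrazol-1-yl, anilino or cyano on that aromatic carbon makes any difference to inhibition.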